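Fluoro to Trifluoromethyl: Expecting Little Change

The compounds below may be only part of what the source reports. "The series", "measured", "known", "first", "only" and "open" are said of these compounds alone.

Measured compounds:
Compound 1, `COc1ccc(C(=O)c2cc(OC)c(OC)c(OC)c2)cc1NC(=O)/C=C/c1ccc(C(F)(F)F)cc1`, gives 1600 nM in a functional assay on HT-29 cells (Homo sapiens) for cytotoxicity, read by MTT assay, with a stated time of 72 h; on this read-out higher numbers stand for weaker inhibition and lower numbers for stronger inhibition.
Compound 2, `COc1ccc(/C=C/C(=O)Nc2cc(C(=O)c3cc(OC)c(OC)c(OC)c3)cc(OC)c2OC)cc1`, gives 3800 nM.
Compound 3, `COc1cc(C(=O)c2cc(OC)c(OC)c(OC)c2)cc(NC(=O)/C=C/c2ccc(F)cc2)c1OC`, gives 1800 nM.

Among these three numbers, compound 3 sits together with compound 1, the two values lying within the usual scatter of each other, while compound 2 is set apart by the step of a 2.1-fold lower number from compound 2 to compound 3 (0.32 log units; beyond the scatter), the one measured step that changes a single group, a swap of methoxy for fluoro.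

Compound 4, `COc1cc(C(=O)c2cc(OC)c(OC)c(OC)c2)cc(NC(=O)/C=C/c2ccc(C(F)(F)F)cc2)c1OC`, shares the core of compound 3 and differs from it only by trifluoromethyl in place of fluoro on an aromatic carbon. Within the data shown here, no measured step makes this exact swap on one shared core. The nearest hint comes from compound 1, which carries a trifluoromethyl on a differently arranged core and gives 1600 nM, against compound 3 with its fluoro at 1800 nM; these two numbers are within the scatter. The expectation for compound 4 is therefore a step of a 1.1-fold lower number from compound 3 to compound 4 (0.02 log units; within the scatter), not beyond the scatter. Compound 4 is estimated at 1700 nM, between 700 nM and 4000 nM.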

Compound 4, half-maximal inhibitory concentration: 1900 nM
The estimate for compound 4 lay 1.1-fold (0.05 log units) below the measured number; the range from low to high includes it.
By their numbers in this assay, from the lowest: compounds 1, 3, 4 and 2 (each within the scatter of the next, the first and the last beyond it).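

In this assay, among these compounds, the swap of fluoro for trifluoromethyl on the aromatic carbon para to a large group gives the first direct reading of these two groups on one shared core: a 1.1-fold higher number from compound 3 to compound 4 (0.02 log units; within the scatter) lies within the scatter, so this read-out does not tell them apart. Starting from methoxy at the same carbon, trifluoromethyl gives a 2.0-fold lower number from compound 2 to compound 4 (0.30 log units; within the scatter), just inside the scatter, while fluoro gives a 2.1-fold lower number from compound 2 to compound 3 (0.32 log units; beyond the scatter), just beyond it, so both steps sit near its edge. A second place also gets a reading, with trifluoromethyl held constant: methoxy in place of hydrogen on an aromatic carbon gives a 1.2-fold higher number from compound 1 to compound 4 (0.07 log units; within the scatter), again within the scatter.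

Going by these compounds, whether an amine or a carboxylic acid at the first carbon would shift the number remains open. Nothing available here accounts for these readings.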